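The source may report more compounds than this note shows. Statements on the series, on what has been measured and on what is new or still open speak of the compounds shown alone.

Measured so far in a functional assay on HeLa cells (Homo sapiens) for cytotoxicity, read by MTT assay; a higher number here means a weaker inhibitor, a lower number a stronger inhibitor:
compound 1 `CC(C)=CC[C@@H](OC(=O)C1CCOC1)C1=CC(=O)c2c(O)ccc(O)c2C1=O` gives 73500 nM
compound 2 `CC(C)=CC[C@@H](OC(=O)CCO)C1=CC(=O)c2c(O)ccc(O)c2C1=O` gives 67600 nM

Compound 2 has the lowest of these two numbers, yet compound 1 sits so close that a 1.1-fold lower number from compound 1 to compound 2 (0.04 log units; within the scatter) lies within the scatter. Compound 3 `CCC(O)(CC)CC(=O)O[C@H](CC=C(C)C)C1=CC(=O)c2c(O)ccc(O)c2C1=O` is built from compound 2 by one change: 1-ethyl-1-hydroxypropyl in place of hydroxymethyl on a saturated chain carbon bound to a carbonyl carbon. Among the measured compounds shown here, the single measured step, a 1.1-fold lower number from compound 1 to compound 2 (0.04 log units; within the scatter), altered the group on the carbonyl carbon, not this chain carbon, and it was within the scatter; no measured step touches the chain carbon itself. The expectation for compound 3 is therefore a step of a 1.1-fold lower number from compound 2 to compound 3 (0.05 log units; within the scatter), nothing beyond the scatter. Compound 3 is estimated at 60000 nM, with a range from 25000 nM to 150000 nM.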

Compound 3, half-maximal inhibitory concentration: 52000 nM
Compound 3: middle estimate off by 1.2-fold (0.06 log units), on the high side; low and high end bracket the measured number.
By their numbers in this assay, from the lowest: compounds 3, 2 and 1 (each within the scatter of the next).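

In this assay, the step of a 1.3-fold lower number from compound 2 to compound 3 (0.11 log units; within the scatter) shows that this saturated chain carbon bound to a carbonyl carbon accepts 1-ethyl-1-hydroxypropyl, with 6 heavy atoms, in place of hydroxymethyl, with 2, without a change beyond the scatter. Replacing oxolan-3-yl with 2-ethyl-2-hydroxybutyl on the carbonyl carbon gives a 1.4-fold lower number from compound 1 to compound 3 (0.15 log units; within the scatter) and is equally undistinguished. No available evidence explains this flat result.

As far as these compounds go, whether an amine, a carboxylic acid or a plain hexyl chain here would move the number beyond the scatter remains open.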